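The source may hold more compounds than are shown below. What is called first, only, known or untested is meant among the compounds shown, and "the series" means these compounds.

Measured compounds:
compound 1, `CC(=O)OCc1ccc2oc(=O)c(C(=O)Sc3cccc(Cl)c3)cc2c1`, giving 76.5% in a functional assay on HT-1080 cells (Homo sapiens), read by transwell migration, with a stated time of 24 h, tested at 0.1 uM; a higher number here means a weaker effect of the compound at the concentration tested, a lower number a stronger effect
compound 2, `CC(=O)OCc1ccc2oc(=O)c(C(=O)Sc3cccc(Br)c3)cc2c1`, giving 79.6% in this assay
compound 3, `CCCCC(=O)OCc1ccc2oc(=O)c(C(=O)Oc3cccc(Br)c3)cc2c1`, giving 92.4% in this assay

Compound 3 stands highest of the three numbers in this assay; its gap to compound 2 and its gap to compound 1 both lie beyond the scatter, so at this concentration it is the weakest of the three measured compounds. Within the data shown here, the one step among measured compounds that differs in a single place, a number 3.1 percentage points higher from compound 1 to compound 2 (within the scatter), concerns the halogen on the aromatic ring and lies within the scatter.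

Compound 4, `CC(C)(C)C(=O)OCc1ccc2oc(=O)c(C(=O)Oc3cccc(Br)c3)cc2c1`, has not yet been measured in this assay. It differs from compound 3 in one place, (tert-butyl in place of butyl on a carbonyl carbon). Among the measured compounds shown here, no measured step touches this part of the molecule: the only single-place step available concerns the halogen and is within the scatter, and the change from compound 3 to compound 4 leaves the count of atoms, donors and acceptors unchanged. On that basis no step beyond the scatter is expected in this assay, in either direction.

Compound 4 is therefore expected to give about 90% in this assay, with a range from 78% to 100%, which corresponds to an expected step of a number 2.4 percentage points lower from compound 3 to compound 4 (within the scatter).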

Compound 4, a percentage reported as activity, at one concentration (the size of the read-out at that concentration, not a potency): 65.2%
Compound 4: middle estimate off by 24.8 percentage points, on the high side; measured number outside the range, below it.
By their numbers in this assay, from the lowest: compound 4; then compounds 1 and 2 (each within the scatter of the next); then compound 3.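

In this assay, the swap of butyl for tert-butyl on the carbonyl carbon gives a number 27.2 percentage points lower from compound 3 to compound 4 (beyond the scatter), so this position responds to how the chain is built, and the lower number means a stronger effect at the concentration tested. Among these compounds, the two groups hold the same atoms, joined differently, and their counts of atoms, donors and acceptors are identical, so these counts do not separate them; the only earlier single-place step, a number 3.1 percentage points higher from compound 1 to compound 2 (within the scatter), concerned the halogen and showed no such response. Nothing available here bears on why the arrangement of these atoms changes the read-out.

The compounds shown leave open whether the step belongs to tert-butyl alone or whether isopropyl, a longer chain or an amine-bearing chain on the same carbonyl carbon would also lower the number. They also leave open whether tert-butyl would give a step of similar size on the core of compound 2, which carries sulfur where compound 3 carries oxygen, and how the effect would look at other concentrations.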